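This account rests on a few compounds, and the source may have more. Where it says the series, first, only, none or still open, it means among the compounds named here.

Among the measured compounds shown here, in a functional assay on HEK293 cells for agonist activity at Bombesin receptor subtype-3 (Homo sapiens), read by luminescence and calcium flux, with a stated time of 10 min (on this read-out lower numbers stand for an effect already at smaller amounts and higher numbers for an effect only at larger amounts of compound), compound 2 `CCC(C)(C)Cc1c[nH]c(CCc2ccc(-n3ncnn3)cc2)n1` gives 89 nM, the lowest of the three numbers so far. Compound 1 `CCC(C)(C)Cc1c[nH]c(CCc2ccc(-c3cccc(C)n3)cc2)n1` gives 102 nM in this assay. Compound 3 `CCC(C)(C)Cc1c[nH]c(CCc2ccc(-n3ccnn3)cc2)n1` gives 93 nM in this assay. The steps of a 1.1-fold lower number from compound 1 to compound 2 (0.06 log units; within the scatter) and a 1.0-fold higher number from compound 2 to compound 3 (0.02 log units; within the scatter) both lie within the scatter, so the three compounds cannot be put in any order, and compound 2 cannot be called the most potent of them.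

Compound 4 `CCC(C)(C)Cc1c[nH]c(CCc2ccc(-c3ccccc3C(=O)O)cc2)n1` differs from compound 2 by 2-carboxyphenyl in place of 2H-tetrazol-2-yl on an aromatic carbon. The two measured steps that bear on this position, a 1.1-fold lower number from compound 1 to compound 2 (0.06 log units; within the scatter) and a 1.1-fold lower number from compound 1 to compound 3 (0.04 log units; within the scatter), show that exchanging one aromatic group for another there left the number essentially unchanged. For the measured compounds named here, none of the measured compounds carries a carboxylic acid, however, so the data give no direct guide to that part of the change, and the expectation must be held loosely. The expected step is a 1.7-fold higher number from compound 2 to compound 4 (0.23 log units; within the scatter), with a wide range to reflect that gap in the data. Compound 4 is therefore estimated at 150 nM, between 50 nM and 600 nM.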

Compound 4, half-maximal effective concentration: 101 nM
The estimate for compound 4 lay 1.5-fold (0.17 log units) above the measured number, and the stated range covers the measured number.
By their numbers in this assay, from the lowest: compounds 2, 3, 4 and 1 (each within the scatter of the next).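

Among the compounds shown here, the 2-carboxyphenyl group brings a carboxylic acid to this position for the first time, with 9 heavy atoms against 5 in the 2H-tetrazol-2-yl and a hydrogen-bond donor that the 2H-tetrazol-2-yl lacks. Even so, in this assay the steps of a 1.1-fold higher number from compound 2 to compound 4 (0.05 log units; within the scatter) and a 1.1-fold higher number from compound 3 to compound 4 (0.04 log units; within the scatter) and a 1.0-fold lower number from compound 1 to compound 4 (0.00 log units; within the scatter) all lie within the scatter, so the tolerance seen among the earlier aromatic groups extends to a ring carrying a carboxylic acid, and the four compounds still cannot be put in any order. No measurement is at hand that would explain why these different groups give such similar numbers.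

Going by these compounds, whether a methyl ester, a primary amide or an amine in place of the carboxylic acid would stay within the same scatter remains open. Also open, on these data alone, is whether a small group such as methoxy, or a saturated ring, at this position would give a step beyond the scatter.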